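A few compounds are considered here, and "the series" means these few. Any claim that something is new, unique, unknown or untested is made for them only; others in the source may bear on it.

Measured compounds:
- compound 1, `Cc1ccc(-n2nc(C)c3c2NC(=O)[C@H](C)S[C@@H]3c2ccc(Oc3ccccc3)cc2)cc1`: 3400 nM
- compound 2, `COc1cccc(-c2ccc([C@H]3S[C@@H](C)C(=O)Nc4c3c(C)nn4-c3ccccc3C)cc2)c1`: 1800 nM
- compound 3, `Cc1nn(-c2ccccc2I)c2c1C(c1ccc(Oc3ccccc3)cc1)SC(C)C(=O)N2`: 1300 nM

These three compounds share one core and were tested in an assay on isolated protein for agonist activity at Bile acid receptor (Homo sapiens), read by AlphaScreen, with a stated time of 30 min; on this read-out higher numbers stand for an effect only at larger amounts of compound and lower numbers for an effect already at smaller amounts. Compound 3 gives the lowest of the three numbers. Compound 2 lies close to it, with a gap that stays within the usual scatter of this kind of measurement, so the two cannot be told apart; compound 1 stands further away, with a gap that does go beyond the scatter.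

Compound 4, `Cc1nn(-c2ccccc2F)c2c1C(c1ccc(Oc3ccccc3)cc1)SC(C)C(=O)N2`, keeps everything of compound 3 except one change: fluoro in place of iodo on an aromatic carbon. Going by the values given here, no measured pair shows this exact exchange, so the expected step rests only on the three numbers above, which all lie within a narrow band. The step from compound 3 to compound 4 is expected to be small, most likely a modest rise in the number, and possibly none beyond the scatter, as a 1.9-fold higher number from compound 3 to compound 4 (0.28 log units; within the scatter). Compound 4 is therefore estimated at 2500 nM in this assay, with a range from 800 nM to 8000 nM.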

Compound 4, half-maximal effective concentration: 3900 nM
For compound 4 the middle estimate is 1.6-fold (0.19 log units) below the measured one; the measured number falls inside the stated range.
By their numbers in this assay, from the lowest: compounds 3, 2, 1 and 4 (each within the scatter of the next, the first and the last beyond it).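

Going by these compounds alone, the exchange of 2-iodophenyl for 2-fluorophenyl is the first change in this set confined to one place, and in this assay it gives a 3.0-fold higher number from compound 3 to compound 4 (0.48 log units; beyond the scatter) and so a modest step, though one that clears the scatter. The group on this aromatic carbon, ortho to a large group, therefore does affect the number, even though one single atom replaces another and the counts of rings, hydrogen-bond donors, hydrogen-bond acceptors and net charge stay the same. Nothing shown here explains why the iodo compound gives the lower number of this pair.

The compounds shown leave open how chloro, bromo, methoxy or an amine would read at this place. From the compounds shown here alone, it is also open whether the same exchange would give a step of similar size alongside the different side group of compound 2.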